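The source may hold more compounds than are shown below. What is called first, only, known or untested is meant among the compounds shown, and "the series" means these compounds.

Measured so far:
compound 1, `Cc1ccc(S(=O)(=O)Nc2ccc3c(c2)C(=O)N(CCNc2ccc(O)c(O)c2)C3=O)cc1`: 28800 nM
compound 2, `Cc1ccc(S(=O)(=O)Nc2ccc3c(c2)C(=O)N(C)C3=O)cc1`: > 200000 nM
compound 3, `Cc1ccc(S(=O)(=O)Nc2ccc3c(c2)C(=O)N(Cc2ccccc2)C3=O)cc1`: > 200000 nM

In an assay on isolated protein for inhibition of lysosomal alpha-glucosidase (Rattus norvegicus), read by colorimetric assay (on this read-out lower numbers stand for stronger inhibition and higher numbers for weaker inhibition), compound 1 gives 28800 nM. For compound 2 the reading > 200000 nM is a limit of the assay and not a number. For compound 3 the reading > 200000 nM is likewise a limit and not a number. Compound 3 therefore stands at the limit of > 200000 nM in this assay, at which 2 of the 3 values shown sit, the weaker end of what the assay can report. Two steps are readable: an at least 6.9-fold higher number from compound 1 to compound 2 (0.84 log units; beyond the scatter), and an at least 6.9-fold higher number from compound 1 to compound 3 (0.84 log units; beyond the scatter). The third, a step that the two limits leave unreadable from compound 2 to compound 3, cannot be sized because both of its ends are limits.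

Compound 4 is `Cc1ccc(S(=O)(=O)Nc2ccc3c(c2)C(=O)N(Cc2ccc(Cl)c(Cl)c2)C3=O)cc1`. It differs from compound 3 in that (3,4-dichlorophenyl in place of phenyl on a saturated chain carbon bound to an amide-type nitrogen in a ring). Within the data shown here, none of the measured steps touches the phenyl of the benzyl group; both readable steps concern what is attached to the amide-type nitrogen in the ring and both run toward the limit. The data give no direction for adding two chlorines to that phenyl. The step expected from compound 3 to compound 4 in this assay, a number no higher from compound 3 to compound 4 (the limit leaves the size open), is therefore taken as none beyond the scatter, with a high chance that only a limit is reported again. Compound 4 is estimated at 200000 nM, within a range from 40000 nM to 1000000 nM.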

Compound 4, half-maximal inhibitory concentration: 122000 nM
For compound 4 the middle estimate is 1.6-fold (0.21 log units) above the measured one; the measured number falls inside the stated range.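

With 3,4-dichlorobenzyl in place of benzyl on the amide-type nitrogen in a ring, this assay returns a number for compound 4, whereas compound 2 and compound 3 each give only a limit of the assay and not a number: the limit of > 200000 nM in this assay, at which 2 of the 4 values shown sit.

The two steps into compound 4 are therefore floors, an at least 1.6-fold lower number from compound 3 to compound 4 (0.21 log units; that floor lies within the scatter) and an at least 1.6-fold lower number from compound 2 to compound 4 (0.21 log units; that floor lies within the scatter), so the true size of either step could be larger, but what is printed does not establish a change beyond the scatter. The side chain of compound 1 still holds a lead over 3,4-dichlorobenzyl, seen in a 4.2-fold higher number from compound 1 to compound 4 (0.63 log units; beyond the scatter), so the two chlorines do not close the gap to that chain.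

The compounds shown leave open whether a single chlorine on the benzyl ring would also give a number, and whether bromine or methoxy would behave like chlorine. They also leave open whether the lead of compound 1 rests on the amine nitrogen of its chain or on its two hydroxyl groups, and what a longer chain ending in 3,4-dichlorophenyl would give.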